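The source may report more compounds than this note shows. Statements on the series, on what has been measured and on what is new or still open speak of the compounds shown alone.

Measured compounds:
- compound 1, `COc1cc(-c2cc(C(=O)Nc3nc4ccc(F)cc4s3)nc3cc(-c4ccccc4)nn23)cc(OC)c1OC`: 32400 nM in a functional assay on ACHN cells (Homo sapiens) for cytotoxicity, read by MTT assay, with a stated time of 48 h; a lower number here means a stronger inhibitor, a higher number a weaker inhibitor
- compound 2, `Cc1cc2nc(NC(=O)c3cc(-c4ccc(F)cc4)n4nc(-c5ccccc5)cc4n3)sc2cc1C`: 33000 nM
- compound 3, `COc1ccc(-c2cc(C(=O)Nc3nc4cc(C)c(C)cc4s3)nc3cc(-c4ccccc4)nn23)cc1`: 22400 nM

Compound 3 gives the lowest number of the three, but its gaps to compound 1 and compound 2 are both within the scatter, so no order among them can be read. Going by the values given here, the only single-point step, a 1.5-fold lower number from compound 2 to compound 3 (0.17 log units; within the scatter), is likewise within the scatter.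

Compound 4, `COc1cc(-c2cc(C(=O)Nc3nc4cc(C)c(C)cc4s3)nc3cc(-c4ccccc4)nn23)cc(OC)c1OC`, differs from compound 3 by 3,4,5-trimethoxyphenyl in place of 4-methoxyphenyl on an aromatic carbon. Among the compounds with values here, no measured step bears directly on this change; compound 1 already carries the trimethoxyphenyl group and its value sits close to that of compound 3. Accordingly, no step beyond the scatter is expected from compound 3 to compound 4 in this assay, a 1.3-fold higher number from compound 3 to compound 4 (0.10 log units; within the scatter). Compound 4 is estimated at 28000 nM, with a range of 12000 nM to 65000 nM.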

Compound 4, half-maximal inhibitory concentration: 3800 nM
Estimate against measurement, compound 4: 7.4-fold (0.87 log units) above, outside the stated range (below it).
By their numbers in this assay, from the lowest: compound 4; then compounds 3, 1 and 2 (each within the scatter of the next).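

In this assay, going by these compounds alone, 3,4,5-trimethoxyphenyl at this position gives the first step beyond the scatter, a 5.9-fold lower number from compound 3 to compound 4 (0.77 log units; beyond the scatter) against 4-methoxyphenyl and an 8.7-fold lower number from compound 2 to compound 4 (0.94 log units; beyond the scatter) against 4-fluorophenyl. The group is not sufficient alone: with it held constant, 5,6-dimethyl-1,3-benzothiazol-2-yl in place of 6-fluoro-1,3-benzothiazol-2-yl on the amide-type nitrogen gives an 8.5-fold lower number from compound 1 to compound 4 (0.93 log units; beyond the scatter) and, among these compounds, the low number appears only with both groups together. On these data alone, it remains open whether a phenyl ring carrying an amine or a longer alkoxy chain keeps this step, and whether it persists with other groups on the amide-type nitrogen. No evidence on the cause of these steps is available.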